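The source may hold more compounds than are shown below. What is called first, only, known or untested is meant among the compounds shown, and "the series" means these compounds.

Compound 1 `O=C(/C=C\Nc1ccc(C(F)(F)F)cc1)c1cn(-c2ccccc2)nc1-c1ccc(F)cc1` and compound 2 `COc1ccc(-c2nn(-c3ccccc3)cc2C(=O)/C=C\Nc2ccc(C(F)(F)F)cc2)cc1` share one core and differ only in the group carried on an aromatic carbon, fluoro in the first and methoxy in the second. In a functional assay on A549 cells (Homo sapiens) for antiproliferative activity, read by MTT assay, with a stated time of 48 h (on this read-out higher numbers stand for weaker inhibition and lower numbers for stronger inhibition), compound 1 gives only a limit, > 50000 nM. In this assay compound 2 likewise gives only a limit, > 50000 nM. The step that the two limits leave unreadable from compound 1 to compound 2 cannot be read, because the limit of > 50000 nM in this assay, at which 2 of the 2 values shown sit, leaves no number on either side of it. Compound 2 therefore stands only at that limit, with no measured value to place it against.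

Compound 3 `COc1cc(-c2nn(-c3ccccc3)cc2C(=O)/C=C\Nc2ccc(C(F)(F)F)cc2)cc(OC)c1OC` is reached from compound 2 by 3,4,5-trimethoxyphenyl in place of 4-methoxyphenyl on an aromatic carbon. For the measured compounds named here, the one measured step that bears on this change, a step that the two limits leave unreadable from compound 1 to compound 2, is unreadable, so the measured data offer neither a size nor a direction for the step in this assay. With both measured compounds sitting at the limit, compound 3 is expected to remain weak in this assay, at an estimated 25000 nM within 2000 nM to 100000 nM. The step of an at least 2.0-fold lower number from compound 2 to compound 3 (0.30 log units; that floor lies within the scatter) that this estimate means is expected to be small, and a further limit is the more likely outcome.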

Compound 3, half-maximal inhibitory concentration: > 50000 nM
Compound 3: only a limit was reported; the forecaster's own chance of this, stated with the estimate: 55%; at least 2.0-fold (0.30 log units) between middle value and limit.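

Compound 3 also gives only a limit, so no new step can be read from compound 1 or compound 2 to compound 3: the limit of > 50000 nM in this assay, at which 3 of the 3 values shown sit.

The compounds shown leave open whether any group at this aromatic carbon gives a measured number in this assay and, if one does, how large its step would be.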